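A few compounds are considered here, and "the series" means these few. Any claim that something is new, unique, unknown or untested is made for them only; others in the source may bear on it.

Measured in a functional assay on MDA-MB-231 cells (Homo sapiens) for antiproliferative activity, read by MTT assay, with a stated time of 48 h; a higher number here means a weaker inhibitor, a lower number a stronger inhibitor:
- compound 1 `COC(=O)/C(=C/c1ccccc1)CN1C(=O)[C@@H](OC)[C@H]1c1ccc(OC)cc1`: 14000 nM
- compound 2 `COC(=O)/C(=C/c1ccccc1)CN1C(=O)[C@@H](OC)[C@H]1c1cccc(F)c1`: 34400 nM
- compound 3 `COC(=O)/C(=C/c1ccccc1)CN1C(=O)[C@@H](OC)[C@H]1c1cccc([N+](=O)[O-])c1`: 14400 nM

Compound 3, at 14400 nM, stands level with compound 1, since the step of a 1.0-fold higher number from compound 1 to compound 3 (0.01 log units; within the scatter) is no larger than the ordinary spread of repeat measurements. Compound 2 stands apart, and the step is a 2.4-fold lower number from compound 2 to compound 3 (0.38 log units; beyond the scatter).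

The next compound, compound 4 `COC(=O)/C(=C/c1ccccc1)CN1C(=O)[C@@H](OC)[C@H]1c1cccc(C(F)(F)F)c1`, keeps the shared core and carries trifluoromethyl in place of nitro on an aromatic carbon.

The closest guide is the step just given between compound 2 and compound 3, also an exchange of one group on an aromatic carbon, and it is modest. Replacing the whole aromatic group of compound 1 gives a 2.5-fold higher number from compound 1 to compound 2 (0.39 log units; beyond the scatter), which is also modest. Among the compounds with values here, no measured step here exceeds that size, so only a small shift is expected, with a slight lean towards the higher number of compound 2. The expected change is a 1.4-fold higher number from compound 3 to compound 4 (0.14 log units; within the scatter), which would not clearly exceed the scatter. For compound 4 the estimated value is 20000 nM, with an expected range from 9000 nM to 42000 nM.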

Compound 4, half-maximal inhibitory concentration: 18200 nM
Compound 4: the middle estimate sits 1.1-fold (0.04 log units) above what was measured; the range from low to high includes it.
By their numbers in this assay, from the lowest: compounds 1, 3, 4 and 2 (each within the scatter of the next, the first and the last beyond it).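

In this assay, putting trifluoromethyl in place of nitro on this aromatic carbon, meta to a large group, gives a 1.3-fold higher number from compound 3 to compound 4 (0.10 log units; within the scatter) and so removes the hydrogen-bond acceptors counted on nitro without a change that can be told from the scatter. Compound 4 also cannot be separated from the other two compounds, with a 1.3-fold higher number from compound 1 to compound 4 (0.11 log units; within the scatter) and a 1.9-fold lower number from compound 2 to compound 4 (0.28 log units; within the scatter) both printed as within the scatter, even though compound 1 and compound 2 stand apart from each other. Nothing available here offers a measured reason for this result.

The compounds shown leave open whether an amine or a carboxylic acid on this same aromatic carbon would move the number beyond the scatter. They also leave open whether trifluoromethyl would behave the same way elsewhere on the ring.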